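A few compounds are considered here, and "the series" means these few. Any claim that something is new, unique, unknown or untested is made for them only; others in the source may bear on it.

Measured so far:

Compound 1 `CC(C)Cc1nn(-c2nccs2)cc1C(=O)NCc1cccc(F)c1`: in a toxicity assay on HepG2 2.2.15 cells (Homo sapiens) for cytotoxicity, read by CCK-8 assay, with a stated time of 8 days (a lower number here means that less compound is tolerated, a higher number that more compound is tolerated), compound 1 reaches only the limit > 100000 nM.
Compound 2 `CC(C)Cc1nn(-c2cccc(F)c2)cc1C(=O)NCc1ccccc1`: compound 2 gives 85900 nM in this assay.
Compound 3 `CC(C)Cc1nn(-c2nccs2)cc1C(=O)NCc1ccc(F)cc1F`: compound 3 gives 83600 nM in this assay.

Compound 2 holds the highest of the two actual numbers, yet its nearest neighbour, compound 3, sits within the usual scatter of it, so the two cannot be told apart. Compound 1 contributes no number at all but sits at the limit of > 100000 nM in this assay, at which 1 of the 3 values shown sits, so it only shows that the tolerated amount is at or beyond that ceiling.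

The new compound, compound 4 `CC(C)Cc1nn(-c2cccc(F)c2)cc1C(=O)NCc1ccncc1`, is built from compound 2 by pyridin-4-yl in place of phenyl on a saturated chain carbon bound to an amide-type nitrogen. For the measured compounds named here, only one measured step touches the same position: an at least 1.1-fold lower number from compound 1 to compound 3 (0.07 log units; that floor lies within the scatter), a swap of one fluorinated ring for another on that chain carbon, which stayed within the scatter. Going by the values given here, no measured pair exchanges a carbon ring for a nitrogen-containing one, so the exact change is untested. Among the compounds with values here, with the only comparable step flat, the expectation is no movement beyond the scatter, although the limit of compound 1 leaves room for a higher number. The step expected is a 1.0-fold higher number from compound 2 to compound 4 (0.02 log units; within the scatter). Compound 4 is expected to give about 90000 nM, between 40000 nM and 100000 nM.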

Compound 4, half-maximal cytotoxic concentration: > 100000 nM
Compound 4 ended at the assay's limit (the forecaster's own chance of this, stated with the estimate: 40%); middle value at least 1.1-fold (0.04 log units) from the limit.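

For the compounds shown here, replacing phenyl with pyridin-4-yl on a saturated chain carbon bound to an amide-type nitrogen gives an at least 1.1-fold higher number from compound 2 to compound 4 (0.06 log units; that floor lies within the scatter), the first measured step at this position that puts a ring nitrogen, and with it a hydrogen-bond acceptor, in place of a ring carbon. The printed floor of this step is within the scatter, so it does not establish a real rise, but it does show that this exchange brings no measured fall in the amount of compound tolerated in this assay. Compound 4 reaches only a limit, and the series now has a second compound whose true value cannot be read, so the full size of the step remains unknown: the limit of > 100000 nM in this assay, at which 2 of the 4 values shown sit.

As far as these compounds go, what a pyridin-3-yl or pyridin-2-yl ring, or a phenyl ring carrying an amine or a carboxylic acid, would do on this chain carbon stays open. Also open, from the compounds shown here alone, is whether pyridin-4-yl would behave the same way on the core of compound 1, where a different ring replaces the fluorophenyl of compound 4.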